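The compounds below may be only part of what the source reports. "The series", "measured", "known", "first", "only" and "open" are said of these compounds alone.

Compound 2 `O=C1O[C@H]([C@@H](O)Cn2cc(CNS(=O)(=O)c3ccc(F)cc3)nn2)C(OCc2ccccc2)=C1OCc1ccccc1` gives 41100 nM in a functional assay on SW-620 cells (Homo sapiens) for antiproliferative activity, read by MTT assay, with a stated time of 72 h (a higher number here means a weaker inhibitor, a lower number a stronger inhibitor), the lowest of the two numbers recorded, with compound 1 `O=C1O[C@H]([C@@H](O)Cn2cc(CNS(=O)(=O)c3ccc(Cl)cc3F)nn2)C(OCc2ccccc2)=C1OCc1ccccc1` sitting at 42400 nM. Going by the values given here, the only measured single change, a 1.0-fold lower number from compound 1 to compound 2 (0.01 log units; within the scatter), bears only indirectly on the exchange examined here. For compound 3 `CCCCCc1ccc(-c2cn(C/C=C3\OC(=O)C(OCc4ccccc4)=C3OCc3ccccc3)nn2)cc1`, this assay reports only a limit, > 100000 nM, which is the limit of > 100000 nM in this assay, at which 1 of the 3 values shown sits. Compound 4 `CCCCCc1ccc(-c2cn(C[C@H](O)[C@H]3OC(=O)C(OCc4ccccc4)=C3OCc3ccccc3)nn2)cc1` differs from compound 2 by 4-pentylphenyl in place of (((4-fluorophenyl)sulfonyl)amino)methyl on an aromatic carbon. Among the compounds with values here, no measured step covers this exchange directly. Compound 3 carries the same 4-pentylphenyl group on another linker and gave only the limit > 100000 nM, and compound 4 is therefore expected to be weaker than compound 2. Compound 4 is estimated at 90000 nM, between 40000 nM and 200000 nM, an expected step of a 2.2-fold higher number from compound 2 to compound 4 (0.34 log units; beyond the scatter).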

Compound 4, half-maximal inhibitory concentration: 12200 nM
Beside the measured number, compound 4's estimate is 7.4-fold (0.87 log units) above it; measured number below the stated range.
By their numbers in this assay, from the lowest: compound 4; then compounds 2 and 1 (each within the scatter of the next). At a limit, above all of these: compound 3.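

In this assay, going by these compounds alone, putting 4-pentylphenyl in place of (((4-fluorophenyl)sulfonyl)amino)methyl on this aromatic carbon gives a 3.4-fold lower number from compound 2 to compound 4 (0.53 log units; beyond the scatter), the first step here beyond the scatter. The entering group has no hydrogen-bond donors or acceptors, so neither the sulfonyl nor its amino hydrogen is required for a measurable number at this position. Compound 3, with the same 4-pentylphenyl group on another linker, reports only a limit: the limit of > 100000 nM in this assay, at which 1 of the 4 values shown sits.

Going by these compounds, how much of the step belongs to the pentyl chain and how much to the phenyl ring remains open. A shorter alkyl chain or a carboxylic acid in place of the pentyl chain would separate the two.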